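From Ethylamino to Diethylamino: One More Ethyl on Nitrogen

The source may hold more compounds than are shown below. What is called first, only, known or untested is meant among the compounds shown, and "the series" means these compounds.

In a functional assay on the whole organism for antagonist activity, with Mus musculus as the target (on this read-out higher numbers stand for an effect only at larger amounts of compound and lower numbers for an effect already at smaller amounts), compound 3 (`CCNC1CCCC1N(C(=O)CC)c1ccc(Cl)c(Cl)c1`) gives 2 mg/kg, the lower of the two numbers in its closest comparison. The other number comes from compound 1 (`CCC(=O)N(c1ccc(Cl)c(Cl)c1)C1CCCC1O`), which gives 9 mg/kg and carries hydroxy where compound 3 carries ethylamino. That exchange on a saturated ring carbon amounts to a 4.5-fold lower number from compound 1 to compound 3 (0.65 log units; beyond the scatter).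

Compound 4 (`CCC(=O)N(c1ccc(Cl)c(Cl)c1)C1CCCC1N(CC)CC`) takes the series one step further: ethyl in place of hydrogen on an amine nitrogen. Put simply, the ethylamino of compound 3 becomes diethylamino in compound 4.

Within the data shown here, no measured step covers this exact change. The step from compound 1 concerns a different exchange at the same ring carbon, so its size cannot simply be carried over. Compound 2 (`CCC(=O)N(c1cccc(C)c1)C1CCCC1N(C)C`) offers only a loose hint. Its amine nitrogen also bears no hydrogen, and in this assay compound 2 gives 1 mg/kg; 1 mg/kg (2 entries), but it differs from compound 3 in more than one place.

No change beyond the scatter is therefore expected, and the direction remains uncertain. The expected change is a 1.3-fold lower number from compound 3 to compound 4 (0.12 log units; within the scatter). Compound 4 is estimated at 1.5 mg/kg, with an expected range from 0.5 mg/kg to 5 mg/kg.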

Compound 4, dose for half-maximal effect: 0.03 mg/kg
Beside the measured number, compound 4's estimate is 50-fold (1.70 log units) above it; measured number below the stated range.
By their numbers in this assay, from the lowest: compound 4; then compound 3; then compound 1.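

In this assay, the added ethyl on the amine nitrogen proves to be the decisive change at this ring carbon, giving a step (a 67-fold lower number from compound 3 to compound 4 (1.82 log units; beyond the scatter)) that is classed as large, whereas the earlier exchange of hydroxy for ethylamino (a 4.5-fold lower number from compound 1 to compound 3 (0.65 log units; beyond the scatter)) was only modest. Taken whole, the exchange of hydroxy for diethylamino on the saturated ring carbon spans a far wider distance (a 300-fold lower number from compound 1 to compound 4 (2.48 log units; beyond the scatter)), so among these compounds an amine nitrogen at this carbon is not enough on its own, and what it carries strongly shapes the dose needed. Nothing shown explains why replacing one hydrogen with ethyl has an effect of this size.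

Going by these compounds, it remains open whether ethyl is special on this nitrogen or whether dipropylamino, or an amine bearing a longer chain, would continue the trend or reverse it. On these data alone, it is also open whether the same ethyl step would carry over to the core of compound 2, which differs from these compounds in more than one place.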